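Toward compound 4: an aromatic ring replaces a saturated one

The compounds below may be only part of what the source reports. "The series", "measured", "known", "first", "only" and "open" are said of these compounds alone.

Of the compounds shown here, three of one shared core have been tested in a functional assay on cells for agonist activity at C-X-C chemokine receptor type 4 (Homo sapiens), read by fluorescence and calcium flux, with a stated time of 90 s; on this read-out higher numbers stand for an effect only at larger amounts of compound and lower numbers for an effect already at smaller amounts. Compound 1, `c1ccc(CN(CCCCN(C[C@H]2Cc3ccccc3CN2)[C@H]2CCCc3cccnc32)Cc2ccccn2)nc1`, gives in this assay only a limit, > 30000 nM. Compound 2, `O=S1(=O)CCC(CNCCCCN(C[C@H]2Cc3ccccc3CN2)[C@H]2CCCc3cccnc32)CC1`, likewise gives only a limit, > 30000 nM. Compound 3, `c1ccc2c(c1)CN[C@@H](CN(CCCCNC1CCNCC1)[C@H]1CCCc3cccnc31)C2`, gives in this assay again only a limit, > 30000 nM. Among the compounds with values here, the one step that can be read as a pair, a step that the two limits leave unreadable from compound 2 to compound 3, therefore has no readable size. Compound 3 thus stands where every measured compound here stands, at the limit of > 30000 nM in this assay, at which 3 of the 3 values shown sit, and nothing in these numbers separates it from compound 1 or compound 2.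

Compound 4, `C(=C/CN(C[C@H]1Cc2ccccc2CN1)[C@H]1CCCc2cccnc21)\CNCc1cccnc1`, is not yet measured. It differs from compound 3 in one place: a group of 11 heavy atoms (9 carbon, 2 nitrogen; one six-membered aromatic ring with 1 hetero atom) in place of a group of 10 heavy atoms (8 carbon, 2 nitrogen; one six-membered non-aromatic ring with 1 hetero atom), on a saturated chain carbon bound to an amine nitrogen. Within the data shown here, no measured step in this assay bears directly on this change, and the single pair that exists gives no size at all. With all three measured compounds sitting at the same limit, the only grounded expectation is that compound 4 also reaches no readable effect, so the step of a number no higher from compound 3 to compound 4 (the limit leaves the size open) is estimated to stay within the scatter. Compound 4 is therefore expected to give about 30000 nM in this assay, with a range from 10000 nM to 100000 nM.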

Compound 4, half-maximal effective concentration: > 30000 nM
Compound 4 was reported as a limit; the forecaster's own chance of this, stated with the estimate: 85%; the middle value lies on the limit itself.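

Within the data shown here, compound 4 gives only a limit in this assay, > 30000 nM, and compound 3 gave only a limit too, so no step between these two compounds can be read. All the compounds shown now sit together: the limit of > 30000 nM in this assay, at which 4 of the 4 values shown sit. The compounds shown leave open whether any compound with this shared core gives a readable effect, and how much the aromatic ring in place of the non-aromatic one matters.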